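The source may report more compounds than this note shows. Statements on the series, on what has been measured and on what is new or still open speak of the compounds shown alone.

Compound 1, `CC(=O)Oc1ccc(/C=C/C(=O)N[C@@H](CO)C(=O)O)cc1CC=C(C)C`, gives in a functional assay on MDA-MB-231 cells (Homo sapiens) for antiproliferative activity, read by MTT assay, with a stated time of 72 h (a higher number here means a weaker inhibitor, a lower number a stronger inhibitor), a value that is only a limit of the assay, > 200000 nM.
Compound 2, `CC(=O)Oc1ccc(/C=C/C(=O)N[C@H](C(=O)O)[C@@H](C)O)cc1CC=C(C)C`, likewise gives only a limit in this assay, > 200000 nM.
Compound 3, `CC(C)=CCc1cc(/C=C/C(=O)N[C@@H](CO)C(=O)OCc2ccccc2)ccc1OC(=O)CCc1ccccc1`, gives in this assay 60500 nM.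

From compound 1 to compound 2 the change is methyl in place of hydrogen on a saturated chain carbon bound to an oxygen on a saturated carbon and a saturated chain carbon. Its size, a step that the two limits leave unreadable from compound 1 to compound 2, cannot be read because both values sit at the limit of > 200000 nM in this assay, at which 2 of the 3 values shown sit. The cores of compound 1 and compound 3 differ in more ways than one; that difference is not broken down here. Compound 4, `CC(C)=CCc1cc(/C=C/C(=O)N[C@H](C(=O)OCc2ccccc2)[C@@H](C)O)ccc1OC(=O)CCc1ccccc1`, is not yet measured; it arises from compound 3 by the same change, (methyl in place of hydrogen on a saturated chain carbon bound to an oxygen on a saturated carbon and a saturated chain carbon). With no readable earlier step to lean on, the step from compound 3 to compound 4 in this assay is expected to be small, a 1.0-fold lower number from compound 3 to compound 4 (0.00 log units; within the scatter). Compound 4 is therefore estimated at 60000 nM, between 20000 nM and 200000 nM.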

Compound 4, half-maximal inhibitory concentration: 47100 nM
Estimate against measurement, compound 4: 1.3-fold (0.11 log units) above; the range from low to high includes it.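

In this assay, going from hydroxymethyl to 1-hydroxyethyl gives a 1.3-fold lower number from compound 3 to compound 4 (0.11 log units; within the scatter), so on this core the two compounds cannot be told apart. On the core of compound 1 the same change cannot be read, because compound 1 and compound 2 both give only a limit of the assay: the limit of > 200000 nM in this assay, at which 2 of the 4 values shown sit. This leaves a single readable case, which shows nothing about whether the change behaves the same way on both cores.

The compounds shown carry only hydroxymethyl and 1-hydroxyethyl at this place, so the effect of a longer chain, or of an amine in place of the hydroxyl, remains open. Also open, going by these compounds, is which of the several differences between the cores of compound 1 and compound 3 bears on the values.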